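Solubility along the proline amide series: the ethylurea analogue

A few compounds are considered here, and "the series" means these few. Any claim that something is new, unique, unknown or untested is made for them only; others in the source may bear on it.

For the measured compounds named here, compound 1 `CC(C)(C)OC(=O)N1CCC[C@H]1C(=O)N1CCC(NS(=O)(=O)c2cc(S(=O)(=O)c3ccccc3)ccc2C(F)(F)F)CC1` is the least soluble of the three compounds measured so far: in a physicochemical assay for solubility (a lower number here means a less soluble compound, a higher number a more soluble compound), compound 1 gives 25000 nM. Compound 2 `O=C1CC[C@@H](C(=O)N2CCC(NS(=O)(=O)c3cc(S(=O)(=O)c4ccccc4)ccc3C(F)(F)F)CC2)N1` gives 100000 nM in this assay, and compound 3 `CN(C)c1ccc(C(=O)N2CCC[C@H]2C(=O)N2CCC(NS(=O)(=O)c3cc(S(=O)(=O)c4ccccc4)ccc3C(F)(F)F)CC2)cc1` gives 100000 nM. Both measured steps leave compound 1 in the same direction and by the same amount: a 4.0-fold higher number from compound 1 to compound 2 (0.60 log units; beyond the scatter) and a 4.0-fold higher number from compound 1 to compound 3 (0.60 log units; beyond the scatter). Each of them alters the group carried on the carbonyl carbon whose other neighbour is the amide-type nitrogen in the ring.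

Compound 4 `CCNC(=O)N1CCC[C@H]1C(=O)N1CCC(NS(=O)(=O)c2cc(S(=O)(=O)c3ccccc3)ccc2C(F)(F)F)CC1` is not yet measured. It differs from compound 1 in one place: ethylamino in place of tert-butoxy on a carbonyl carbon. The change is thus of the same kind as the two measured ones, at the same carbonyl carbon, and both of those moved the number upward beyond the scatter. Going by the values given here, no measured step shows exactly this exchange, so the size is uncertain, but a modest rise in this assay is the reasonable expectation, close to what the two known steps gave.

Compound 4 is therefore expected to give about 70000 nM in this assay, within 25000 nM to 160000 nM, which is an expected step of a 2.8-fold higher number from compound 1 to compound 4 (0.45 log units; beyond the scatter).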

Compound 4, solubility: 100000 nM
For compound 4 the middle estimate is 1.4-fold (0.15 log units) below the measured one; the measured number falls inside the stated range.
By their numbers in this assay, from the lowest: compound 1; then compounds 2, 3 and 4 (each within the scatter of the next).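

Replacing tert-butoxy with ethylamino on this carbonyl carbon gives, in this assay, a 4.0-fold higher number from compound 1 to compound 4 (0.60 log units; beyond the scatter), making it the third group at this position to differ from compound 1 in the same direction. The groups that replace it do not separate from one another: ethylamino in place of 4-(dimethylamino)phenyl gives no change at the digits printed from compound 3 to compound 4 (within the scatter), and 1-(ethylcarbamoyl)pyrrolidin-2-yl in place of 5-oxopyrrolidin-2-yl gives no change at the digits printed from compound 2 to compound 4 (within the scatter). Among these four compounds, then, the only separation lies between compound 1, which carries the tert-butoxycarbonyl group, and the other three, and none of the three goes against this.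

Nothing available explains the rise. Still open, as far as these compounds go, is whether the same picture holds for a methoxy group, a longer chain such as hexylamino, or a carboxylic acid on this carbonyl carbon, and whether any group here separates from compounds 2, 3 and 4 in this assay.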